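This account rests on a few compounds, and the source may have more. Where it says the series, first, only, none or still open, it means among the compounds named here.

Measured so far:
Compound 1, `CC(O)(C(=O)Nc1ccc(S(=O)(=O)c2ccc(C#N)cc2)cc1)C(F)(F)F` — in a functional assay (Cavia porcellus) with sulfonylurea receptors; K-ATP channels (Homo sapiens) as the target (a lower number here means a stronger inhibitor, a higher number a weaker inhibitor), compound 1 gives > 30000 nM.
Compound 2, `CC(O)(C(=O)Nc1ccc(S(=O)(=O)c2ccccc2)cc1[N+](=O)[O-])C(F)(F)F` — in this assay compound 2 gives 7900 nM.

The value for compound 1 is a limit of this assay, not a measured number: it stands at the limit of > 30000 nM in this assay, at which 1 of the 2 values shown sits, so only a floor on its weakness is known. For the measured compounds named here, compound 2 differs from compound 1 in more than one place, so no single step between them can be drawn; its value is a plain number.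

Compound 3, `CC(O)(C(=O)Nc1ccc(S(=O)(=O)c2ccc([N+](=O)[O-])cc2)cc1)C(F)(F)F`, has not yet been measured in this assay. It differs from compound 1 by one change: nitro in place of cyano on an aromatic carbon. Going by the values given here, no measured pair here shows what this exchange does in this assay.

The step of a number no higher from compound 1 to compound 3 (the limit leaves the size open) is expected to lie within the usual scatter, with compound 3 most likely again reported only as a limit. Compound 3 is estimated at 30000 nM, with a range from 10000 nM to 80000 nM.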

Compound 3, half-maximal inhibitory concentration: > 30000 nM
Compound 3: only a limit was reported; the forecaster's own chance of this, stated with the estimate: 65%; the middle value sits exactly at the limit.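

For the compounds shown here, compound 1 and compound 3 are both reported only as limits, not as numbers, so no step between them can be read: the limit of > 30000 nM in this assay, at which 2 of the 3 values shown sit. The compounds shown leave open how weak either compound really is, and so what nitro in place of cyano does.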